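Replacing a Phenyl Group with a tert-Butoxymethyl Chain

A few compounds are considered here, and "the series" means these few. Any claim that something is new, unique, unknown or untested is made for them only; others in the source may bear on it.

Compound 1 `Cc1cccc([C@@H](O)C(=O)N2N=CC[C@H]2C(=O)NCc2cc(Cl)ccc2-n2cnnn2)c1`: 830 nM
Compound 2 `O=C(NCc1cc(Cl)ccc1-n1cnnn1)[C@@H]1CC=NN1C(=O)[C@H](O)c1ccccc1F`: 1100 nM
Compound 3 `O=C(NCc1cc(Cl)ccc1-n1cnnn1)[C@@H]1CC=NN1C(=O)[C@H](O)c1ccccc1`: 840 nM

All three values were obtained in a functional assay on a cell-free system (plasma, Homo sapiens), with a stated time of 3 min; a lower number here means a stronger inhibitor, a higher number a weaker inhibitor. Compound 3 stands second highest of the three numbers; its nearest neighbour is compound 1, at a 1.0-fold higher number from compound 1 to compound 3 (0.01 log units; within the scatter), and its furthest is compound 2, at a 1.3-fold lower number from compound 2 to compound 3 (0.12 log units; within the scatter). The remaining pair gives a 1.3-fold higher number from compound 1 to compound 2 (0.12 log units; within the scatter). Every measured step therefore lies within the scatter, and each of them only varies a substituent on the aromatic ring that sits on the saturated chain carbon bound to a carbonyl carbon and an oxygen on a saturated carbon.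

Compound 4 `CC(C)(C)OC[C@@H](O)C(=O)N1N=CC[C@H]1C(=O)NCc1cc(Cl)ccc1-n1cnnn1` goes further than any of those steps: (tert-butoxy)methyl in place of phenyl on a saturated chain carbon bound to a carbonyl carbon and an oxygen on a saturated carbon. For the measured compounds named here, no measured step bears directly on this exchange, since the ring itself is removed rather than decorated. The measured steps only show that hydrogen, methyl and fluoro on that ring leave this assay unchanged within scatter. On that basis the number for compound 4 is expected to stay near that of compound 3, with a step of a 1.8-fold higher number from compound 3 to compound 4 (0.25 log units; within the scatter) carrying wide uncertainty. Compound 4 is estimated at 1500 nM, within a range from 500 nM to 5000 nM.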

Compound 4, half-maximal inhibitory concentration: 750 nM
The estimate for compound 4 lay 2.0-fold (0.30 log units) above the measured number; the range from low to high includes it.
By their numbers in this assay, from the lowest: compounds 4, 1, 3 and 2 (each within the scatter of the next).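

Taking the aromatic ring away from the saturated chain carbon bound to a carbonyl carbon and an oxygen on a saturated carbon leaves the number in this assay within the scatter: the step for (tert-butoxy)methyl in place of phenyl is small (a 1.1-fold lower number from compound 3 to compound 4 (0.05 log units; within the scatter)), and the same holds against the 2-fluorophenyl (a 1.5-fold lower number from compound 2 to compound 4 (0.17 log units; within the scatter)) and the 3-methylphenyl (a 1.1-fold lower number from compound 1 to compound 4 (0.04 log units; within the scatter)). The earlier compounds shown here only showed that substituents on that ring could vary, whereas compound 4 shows that, in this series, inhibition at this level does not depend on an aromatic ring at this place, since a chain with no ring and one hydrogen-bond acceptor serves equally well. Nothing available here accounts for the phenyl and the (tert-butoxy)methyl group giving matching numbers.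

The compounds shown cannot separate the contribution of the ether oxygen from that of the tert-butyl end, which a plain neopentyl chain or a hydroxymethyl group would address. As far as these compounds go, it also remains open whether any group at this place moves the number beyond the scatter, for instance an amine or a carboxylic acid.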